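Chloro to bromo on the anilide ring: a tolerability check

This account rests on a few compounds, and the source may have more. Where it says the series, first, only, none or still open, it means among the compounds named here.

Compound 1 `O=C(Nc1ccccc1)c1c(NO)cc(-c2cccs2)oc1=O`: > 20000 nM in an ADME assay on Huh-7 cells (Homo sapiens) for cytotoxicity, with a stated time of 3 days; a lower number here means that less compound is tolerated, a higher number that more compound is tolerated.
Compound 2 `O=C(Nc1ccc(Cl)cc1)c1c(NO)cc(-c2cccs2)oc1=O`: > 20000 nM in this assay.

For compound 1 the value > 20000 nM is a limit of the assay, not a measured number. For compound 2 the value > 20000 nM is likewise a limit. Both values sit at the limit of > 20000 nM in this assay, at which 2 of the 2 values shown sit, so the step that the two limits leave unreadable from compound 1 to compound 2 cannot be sized, and compound 2 can only be placed at that limit, with nothing beyond it known.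

Compound 3 `O=C(Nc1ccc(Br)cc1)c1c(NO)cc(-c2cccs2)oc1=O` is reached by a single change: bromo in place of chloro on an aromatic carbon. For the measured compounds named here, the only measured step, from hydrogen to chloro, gave no readable size, so there is no measured guide to how this halogen swap moves this assay. Since compound 2 stands at the limit of > 20000 nM in this assay, at which 2 of the 2 values shown sit, compound 3 is expected to remain there too, at an estimated 30000 nM within 12000 nM to 100000 nM, which means an expected step that the limit leaves unreadable from compound 2 to compound 3.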

Compound 3, half-maximal cytotoxic concentration: > 20000 nM
Compound 3 gave a limit, no number; the forecaster's own chance of this, stated with the estimate: 85%; the middle value lies beyond the limit too.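

Compound 3 gives only a limit in this assay, so neither its step from compound 1 nor its step from compound 2 can be read: the limit of > 20000 nM in this assay, at which 3 of the 3 values shown sit.

Where the true tolerated concentrations of compound 1, compound 2 and compound 3 lie, and whether hydrogen, chloro and bromo differ at all, stays open.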